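The source may report more compounds than this note shows. Statements on the series, on what has been measured and on what is new or still open speak of the compounds shown alone.

Measured compounds:
compound 1, `Cc1cc(F)c(S(C)(=O)=O)cc1C(=O)N=C(N)N`, 44 nM
compound 2, `CS(=O)(=O)c1cc(C(=O)N=C(N)N)c(F)cc1F`, 630 nM
compound 3, `Cc1cc(-c2cc(C(F)(F)F)cc(C(F)(F)F)c2)c(S(C)(=O)=O)cc1C(=O)N=C(N)N`, 2800 nM

For the measured compounds named here, in a functional assay for inhibition of sodium/hydrogen exchanger (Oryctolagus cuniculus) (on this read-out higher numbers stand for weaker inhibition and lower numbers for stronger inhibition), compound 1 gives the lowest of the three numbers: compound 2 sits at a 14-fold higher number from compound 1 to compound 2 (1.16 log units; beyond the scatter), and compound 3, for which no single-point step is drawn, lies further off at 2800 nM, whereas compound 1 gives 44 nM.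

The unmeasured compound 4, `Cc1cc(-c2ccco2)c(S(C)(=O)=O)cc1C(=O)N=C(N)N`, is reached from compound 1 by one change: furan-2-yl in place of fluoro on an aromatic carbon. The measured step from compound 1 to compound 2 changes the methyl group, not the fluoro, and so bears on the new step only in showing that a single exchange on the shared core can move this assay well beyond the scatter. The pair of compound 1 and compound 3 is closer in kind: compound 3 carries a larger aromatic ring where compound 1 carries fluoro, and its number is far higher. Compound 4 places a smaller five-membered aromatic ring at the same position. The account therefore expects the number for compound 4 to rise above compound 1, by a step of about a 9.1-fold higher number from compound 1 to compound 4 (0.96 log units; beyond the scatter), though by less than compound 3 shows. The estimate for compound 4 is 400 nM, with a range from 100 nM to 1600 nM.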

Compound 4, half-maximal inhibitory concentration: 16 nM
Beside the measured number, compound 4's estimate is 25-fold (1.40 log units) above it; measured number outside the range, below it.
By their numbers in this assay, from the lowest: compound 4; then compound 1; then compound 2; then compound 3.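

In this assay, the place ortho to a methylsulfonyl group now proves able to carry an aromatic ring with no rise in the number: furan-2-yl in place of fluoro gives a 2.8-fold lower number from compound 1 to compound 4 (0.44 log units; beyond the scatter) and so takes the series to a lower number rather than a higher one. Until now the only ring at this place was the phenyl ring with its trifluoromethyl groups in compound 3 at 2800 nM against compound 4 at 16 nM on the same core, so the high number of compound 3 cannot be read as the mark of any aromatic ring here; what matters is which ring stands there. Nothing among the data shown accounts for the gain over fluoro or for the gap between these two rings.

From the compounds shown here alone, it stays open how a plain phenyl ring, a thiophen-2-yl ring, or a non-aromatic group such as an amine or a short alkyl chain would read at this place, and so whether the lower number belongs to furan-2-yl in particular. Going by these compounds, it is also open whether furan-2-yl would give a similar step with fluoro in place of the methyl group on the core.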